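Repeating a tert-Butyl Addition on a Methoxy Core

The source may hold more compounds than are shown below. What is called first, only, known or untested is meant among the compounds shown, and "the series" means these compounds.

Measured so far:
compound 1 `O=C(N/N=C/c1ccccc1O)c1cc(-c2ccc(Cl)cc2)nn1Cc1ccccc1` — 25000 nM
compound 2 `CC(C)(C)c1ccc(Cn2nc(-c3ccc(Cl)cc3)cc2C(=O)N/N=C/c2ccccc2O)cc1` — 36000 nM
compound 3 `COc1ccc(-c2cc(C(=O)N/N=C/c3ccccc3O)n(Cc3ccccc3)n2)cc1` — 23000 nM

These three compounds were tested in a functional assay on A549 cells (Homo sapiens) for cytotoxicity, read by MTT assay, with a stated time of 48 h; a higher number here means a more soluble compound, a lower number a less soluble compound. Compound 2 differs from compound 1 by tert-butyl in place of hydrogen on an aromatic carbon, a change that gave a 1.4-fold higher number from compound 1 to compound 2 (0.16 log units; within the scatter). Compound 3 differs from compound 1 by methoxy in place of chloro on an aromatic carbon, with a 1.1-fold lower number from compound 1 to compound 3 (0.04 log units; within the scatter). Compound 4 `COc1ccc(-c2cc(C(=O)N/N=C/c3ccccc3O)n(Cc3ccc(C(C)(C)C)cc3)n2)cc1` has not yet been measured. It differs from compound 3 by tert-butyl in place of hydrogen on an aromatic carbon, which is the same change that turns compound 1 into compound 2, made at the same place on the ring. The step from compound 3 to compound 4 in this assay is expected to be a 1.3-fold higher number from compound 3 to compound 4 (0.12 log units; within the scatter), because the same change earlier gave a 1.4-fold higher number from compound 1 to compound 2 (0.16 log units; within the scatter). Compound 4 is therefore estimated at 30000 nM, with a likely range from 15000 nM to 60000 nM.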

Compound 4, solubility: 22000 nM
For compound 4 the middle estimate is 1.4-fold (0.13 log units) above the measured one; the measured number falls inside the stated range.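

In this assay carrying tert-butyl in place of hydrogen over to the core of compound 3 gives a 1.0-fold lower number from compound 3 to compound 4 (0.02 log units; within the scatter) and the two cores agree: the same change on two cores in this assay, a 1.4-fold higher number (0.16 log units; within the scatter) from compound 1 to compound 2 and a 1.0-fold lower number (0.02 log units; within the scatter) from compound 3 to compound 4, 1.5-fold (0.18 log units) apart, within the scatter of two such steps. Methoxy in place of chloro, read on the core that carries tert-butyl, gives a 1.6-fold lower number from compound 2 to compound 4 (0.21 log units; within the scatter) and again the two cores agree: the same change on two cores in this assay, a 1.1-fold lower number (0.04 log units; within the scatter) from compound 1 to compound 3 and a 1.6-fold lower number (0.21 log units; within the scatter) from compound 2 to compound 4, 1.5-fold (0.18 log units) apart, within the scatter of two such steps. Among the compounds shown here, all of these steps lie within the scatter, so the four compounds show only that neither change shifts the number measurably on these two cores, not that a change with a real effect would carry over from one core to the other.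

The compounds shown leave open whether a different group at the same place on the ring, such as an amine or a carboxylic acid, would give a step beyond the scatter. They also leave open whether any such step would repeat on both cores.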